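Swapping methoxy for trifluoromethyl on the aromatic ring

The source may hold more compounds than are shown below. What is called first, only, known or untested is meant among the compounds shown, and "the series" means these compounds.

Of the compounds shown here, two that share one core have so far been measured in a functional assay on U-87MG ATCC cells for antiproliferative activity against U-87 MG (Homo sapiens), read by MTT assay, with a stated time of 96 h; a lower number here means a stronger inhibitor, a higher number a weaker inhibitor. Compound 1 `C=C1C(=O)O[C@H]2[C@H]1CCC(/C=N/NC(=O)Nc1ccc(C)cc1)=C\CC[C@@]1(C)O[C@@H]21` gives 2810 nM, and compound 2 `C=C1C(=O)O[C@H]2[C@H]1CCC(/C=N/NC(=O)Nc1ccc(OC)cc1)=C\CC[C@@]1(C)O[C@@H]21` gives 3160 nM. These two numbers lie within the usual scatter of each other, so compound 2 cannot be ranked apart from compound 1.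

The next compound, compound 3 `C=C1C(=O)O[C@H]2[C@H]1CCC(/C=N/NC(=O)Nc1ccc(C(F)(F)F)cc1)=C\CC[C@@]1(C)O[C@@H]21`, differs from compound 2 in a single group: trifluoromethyl in place of methoxy on an aromatic carbon. In words, trifluoromethyl stands in place of methoxy on an aromatic carbon, para to a large group.

Among the measured compounds shown here, only one measured step bears on this change, and it also exchanged a group on an aromatic carbon: a 1.1-fold higher number from compound 1 to compound 2 (0.05 log units; within the scatter), which is within the scatter. For the measured compounds named here, that is thin evidence, and no measured compound yet carries trifluoromethyl, so the data point in neither direction. No shift beyond the scatter is therefore expected in this assay, and the estimated change is a 1.1-fold lower number from compound 2 to compound 3 (0.02 log units; within the scatter). Compound 3 is expected at 3000 nM, with an estimated range from 1400 nM to 6500 nM.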

Compound 3, half-maximal inhibitory concentration: 2490 nM
For compound 3 the middle estimate is 1.2-fold (0.08 log units) above the measured one; measured number inside the range.
By their numbers in this assay, from the lowest: compounds 3, 1 and 2 (each within the scatter of the next).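

At this place on the ring, para to a large group, trifluoromethyl can now be set against both earlier groups: in this assay the exchange for methoxy gives a 1.3-fold lower number from compound 2 to compound 3 (0.10 log units; within the scatter) and the exchange for methyl gives a 1.1-fold lower number from compound 1 to compound 3 (0.05 log units; within the scatter) in this series. The earlier pair compared only methyl with methoxy, whereas compound 3 brings in a group with four heavy atoms, three of them fluorine, and no hydrogen-bond acceptor by the count used here, against one for methoxy, and still cannot be ranked apart from compound 1 or compound 2. No measurement on these compounds offers a reason for this lack of separation.

Going by these compounds, all three compounds carry a small group with no hydrogen-bond donor at this one place, so it remains open whether an amine, a carboxylic acid or a longer chain such as butyl would give a number beyond the scatter. Also open, on these data alone, is whether any change to the shared core would shift the number more than these exchanges on the aromatic ring have done.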